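A few compounds are considered here, and "the series" means these few. Any claim that something is new, unique, unknown or untested is made for them only; others in the source may bear on it.

Notes on the series. Compound 1 `CC(Oc1ccccc1-c1ccncc1)C1=NCCN1`, compound 2 `CC(Oc1ccccc1-c1ccccc1O)C1=NCCN1` and compound 3 `Cc1cccc(-c2ccccc2OC(C)C2=NCCN2)c1` share one core and differ only in the aryl group on an aromatic carbon. Going by the values given here, in a functional assay on CHO cells for agonist activity at Alpha-2C adrenergic receptor (Homo sapiens) (a lower number here means a smaller maximal response, a higher number a larger maximal response), compound 3 gives 0.6, the only number among the three. Compound 1 reaches only the assay limit, < 0.3. Compound 2 likewise sits at the limit, < 0.3. The measured steps are a number at least 0.30 higher from compound 1 to compound 3 (beyond the scatter) and a number at least 0.30 higher from compound 2 to compound 3 (beyond the scatter), both beyond the scatter, while a step that the two limits leave unreadable from compound 1 to compound 2.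

Compound 4 `CC(Oc1ccccc1-c1ccc(O)cc1)C1=NCCN1` is not yet measured; it differs from compound 3 in that (4-hydroxyphenyl in place of 3-methylphenyl on an aromatic carbon). The step a number at least 0.30 higher from compound 2 to compound 3 (beyond the scatter) bears most directly: read the other way, 2-hydroxyphenyl in place of 3-methylphenyl fell to the limit, so a hydroxyphenyl entering is expected to lower the response, possibly to the limit again. For compound 4 in this assay the estimate is 0.3, range 0.1 to 0.5. The expected step is a number 0.30 lower from compound 3 to compound 4 (beyond the scatter).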

Compound 4, intrinsic activity: the largest response reached, as a fraction of the reference agonist's: < 0.3
Compound 4: only a limit was reported; the forecaster's own chance of this, stated with the estimate: 50%; the middle value sits exactly at the limit.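

In this assay, 4-hydroxyphenyl in place of 3-methylphenyl gives a number at least 0.30 lower from compound 3 to compound 4 (beyond the scatter), so moving from 2-hydroxyphenyl to 4-hydroxyphenyl does not recover a readable response. Of the four aryl groups at this position, only 3-methylphenyl gives a number, and the other three end at an assay limit: the limit of < 0.3 in this assay, at which 3 of the 4 values shown sit. The steps among compound 1, compound 2 and compound 4 cannot be read, as each joins two limits.

As far as these compounds go, whether the methyl group itself matters remains open, as unsubstituted phenyl, 4-methylphenyl and 3-methoxyphenyl do not appear here. Also open, from the compounds shown here alone, is how 3-hydroxyphenyl would compare with 3-methylphenyl at this position.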